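The compounds below may be only part of what the source reports. "The series", "measured", "known", "first", "only" and "open" are said of these compounds alone.

Compound 1 `Cc1ccccc1-c1nn(-c2ccc(F)cc2F)cc1CNCCN1CCCCC1`: > 20000 nM
Compound 2 `Cc1ccccc1-c1nn(-c2ccc(F)cc2F)cc1CNCCCCO`: > 20000 nM
Compound 3 `Cc1ccccc1-c1nn(-c2ccc(Br)cc2)cc1CNCCN1CCN(C)CC1`: 9600 nM

In an ADME assay on Huh-7 cells (Homo sapiens) for cytotoxicity (on this read-out higher numbers stand for lower toxicity in this test and lower numbers for higher toxicity in this test), compound 2 reaches only the limit of the test, > 20000 nM. Compound 1 likewise stops at a limit, > 20000 nM. Compound 3 gives a measured number, 9600 nM. Among the measured compounds shown here, the only measured step, a step that the two limits leave unreadable from compound 1 to compound 2, cannot be read in size. Compound 4 `Cc1ccccc1-c1nn(-c2ccc(F)cc2F)cc1CNCCCN1CCN(C)CC1` differs from compound 2 in one place: 4-methylpiperazin-1-yl in place of hydroxymethyl on a saturated chain carbon, three bonds along the chain from an amine nitrogen. For the measured compounds named here, no measured step follows this exact change, and the one step available stays unreadable, so no size or direction can be drawn from it beyond the scatter. Compound 3, which carries the same entering group, does sit under the limit. Compound 4 is therefore expected near the limit, estimated at 15000 nM (range 6000 nM to 40000 nM), an expected step of an at least 1.3-fold lower number from compound 2 to compound 4 (0.12 log units; that floor lies within the scatter).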

Compound 4, half-maximal cytotoxic concentration: > 20000 nM
Compound 4 gave a limit, no number; the forecaster's own chance of this, stated with the estimate: 45%; at least 1.3-fold (0.12 log units) between middle value and limit.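

Among the compounds shown here, compound 1, compound 2 and compound 4 each give a limit rather than a number, so no step among them can be read: the limit of > 20000 nM in this assay, at which 3 of the 4 values shown sit. As far as these compounds go, whether these three compounds truly differ from one another in this test stays open.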